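Dog clearance: from a methoxypyrimidine to a dihydrobenzofuran

The compounds below may be only part of what the source reports. "The series", "measured", "known", "first", "only" and "open" are said of these compounds alone.

This account follows three compounds that share one core, all examined in an in vivo ADME assay on the whole organism (Canis lupus familiaris) for pharmacokinetics; on this read-out higher numbers stand for fast clearance and lower numbers for slow clearance. Compound 1 `CC(C)c1ncc([C@@H](CCCCCCc2ccc3c(n2)NCCC3)CC(=O)O)cn1` carries an isopropyl pyrimidine, but in this assay compound 1 is recorded as "not determined" (no result reported), so no number is available for it. Within the data shown here, compound 2 `COc1ncc([C@@H](CCCCCCc2ccc3c(n2)NCCC3)CC(=O)O)cn1` is therefore the only compound with a number: in this assay compound 2 gives 4.3 mL/min/kg, which is the sole point of reference here, with nothing else to compare it against. Compound 3 `O=C(O)C[C@H](CCCCCCc1ccc2c(n1)NCCC2)c1ccc2c(c1)OCC2` has not yet been measured. It differs from compound 2 by a group of 9 heavy atoms (8 carbon, 1 oxygen; one five-membered non-aromatic ring with 1 hetero atom, one six-membered aromatic ring of carbon only) in place of a group of 8 heavy atoms (5 carbon, 2 nitrogen, 1 oxygen; one six-membered aromatic ring with 2 hetero atoms), on a saturated chain carbon bound to two saturated chain carbons. Among the measured compounds shown here, no step between two measured compounds is available, so the expected change rests on this single reference. The step from compound 2 to compound 3 is expected to be a 1.5-fold higher number from compound 2 to compound 3 (0.18 log units; within the scatter), a modest rise that may not exceed the usual scatter. Compound 3 is expected to give 6.5 mL/min/kg, within a range from 2.5 mL/min/kg to 16 mL/min/kg.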

Compound 3, clearance in the Canis lupus familiaris assay: 7.9 mL/min/kg
Compound 3: the middle estimate sits 1.2-fold (0.08 log units) below what was measured; measured number inside the range.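

In the Canis lupus familiaris assay, replacing the 2-methoxypyrimidin-5-yl group with the group carrying a five-membered non-aromatic ring gives a 1.8-fold higher number from compound 2 to compound 3 (0.26 log units; within the scatter). In a physicochemical assay for lipophilicity (on this read-out lower numbers stand for lower lipophilicity and higher numbers for higher lipophilicity), compound 2 gives 0.65 and compound 3 gives 2.39. In the physicochemical assay that is a number 1.74 log units higher from compound 2 to compound 3 (beyond the scatter), so at this saturated chain carbon, on this one pair, a large step on that read-out came with a step inside the scatter in the Canis lupus familiaris assay.

A single pair cannot show whether the two read-outs would part in the same way for other groups at this place. A plain phenyl ring or a pyridine ring bearing a trifluoromethyl group could give a different result in the Canis lupus familiaris assay, and the compounds shown do not settle this.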